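Swapping Nitro for Methoxy on a Thiourea

The source may hold more compounds than are shown below. What is called first, only, known or untested is meant among the compounds shown, and "the series" means these compounds.

Of the compounds shown here, three have been measured in an assay for inhibition of Polyunsaturated fatty acid 5-lipoxygenase (Homo sapiens), read by spectrophotometry, tested at 10 uM; on this read-out lower numbers stand for less inhibition and higher numbers for more inhibition at the one concentration tested (going by the name of the read-out). Compound 1 `O=C(c1ccccc1)c1sc(N2CCCCC2)nc1-c1ccccc1` gives 85.2%, compound 2 `COc1ccc(C(=O)NC(=S)N(C)Cc2ccccc2)cc1` gives 26.5%, and compound 3 `O=C(NC(=S)N1CCN(c2ccccc2)CC1)c1ccc([N+](=O)[O-])cc1` gives 76.6%. Compound 3 holds the second highest of the three numbers: it sits within the scatter of compound 1, and far beyond the scatter above compound 2. Compound 4 `COc1ccc(C(=O)NC(=S)N2CCN(c3ccccc3)CC2)cc1` has not yet been measured. It differs from compound 3 in one place: methoxy in place of nitro on an aromatic carbon. Within the data shown here, no measured pair shows this change alone. Compound 2 also carries a methoxy and reads low, but it differs from compound 4 elsewhere too, so those two values give no clean guide. The step of a number 26.6 percentage points lower from compound 3 to compound 4 (beyond the scatter) is expected to be a moderate loss, somewhat beyond the scatter. For compound 4 the estimate is 50%, likely between 25% and 75%.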

Compound 4, a percentage reported as inhibition, at one concentration (the size of the read-out at that concentration, not a potency): 36.8%
The estimate for compound 4 lay 13.2 percentage points above the measured number; the range from low to high includes it.
By their numbers in this assay, from the lowest: compound 2; then compound 4; then compounds 3 and 1 (each within the scatter of the next).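

Among these compounds, this is the first pair that isolates the swap, with the rest of the molecule held constant. In this assay, replacing nitro with methoxy on the aromatic carbon para to a large group gives a number 39.8 percentage points lower from compound 3 to compound 4 (beyond the scatter) and so shows that this single position can strongly change the read-out. Nothing available here explains the loss. Going by these compounds, it remains open whether nitro helps inhibition or methoxy harms it. Analogues carrying hydrogen, chlorine or an amine on the same carbon would help separate those two readings.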